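Hydantoin linker saturation in a fluoronaphthyl pyridone series

The compounds below may be only part of what the source reports. "The series", "measured", "known", "first", "only" and "open" are said of these compounds alone.

Measured so far:
compound 1 `CC(C)C(/C=C1\NC(=O)NC1=O)c1ccc(-c2ccc3cccc(F)c3c2)[nH]c1=O`, 43 nM
compound 2 `Cc1cc(C(/C=C2\OC(=O)NC2=O)C(C)C)c(=O)[nH]c1-c1ccc2cccc(F)c2c1`, 23 nM
compound 3 `CC(C)[C@@H](c1ccc(-c2ccc3cccc(F)c3c2)[nH]c1=O)[C@@H]1OC(=O)NC1=O`, 85 nM

In an assay on membranes from Chem-1 cells for displacement of a labelled ligand from prostaglandin E2 receptor EP3 subtype (Homo sapiens), read by scintillation counting, with a stated time of 2 h (on this read-out lower numbers stand for stronger inhibition and higher numbers for weaker inhibition), compound 1 gives 43 nM, the second highest of the three numbers. Its nearest neighbour is compound 2 at 23 nM, and the furthest is compound 3 at 85 nM; both gaps fall within the usual scatter, so no order among the three can be claimed.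

Compound 4 `CC(C)C(c1ccc(-c2ccc3cccc(F)c3c2)[nH]c1=O)C1NC(=O)NC1=O` differs from compound 1 by a group of 7 heavy atoms (3 carbon, 2 nitrogen, 2 oxygen; one five-membered non-aromatic ring with 2 hetero atoms) in place of a group of 8 heavy atoms (4 carbon, 2 nitrogen, 2 oxygen; one five-membered non-aromatic ring with 2 hetero atoms), on a saturated chain carbon bound to an aromatic carbon and a saturated chain carbon. Going by the values given here, no step between measured compounds that differ in this one place is available. Compound 2 and compound 3 share the same kind of ring but differ in several places; compound 2 gives 23 nM and compound 3 gives 85 nM, which is the only hint on record for replacing an exocyclic alkylidene ring by a directly attached saturated ring.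

The expected direction for compound 4 is toward a higher number, with a step of modest size, a 2.8-fold higher number from compound 1 to compound 4 (0.45 log units; beyond the scatter), that may or may not exceed the scatter. The estimate for compound 4 in this assay is 120 nM, with a range from 40 nM to 350 nM.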

Compound 4, inhibition constant: 50 nM
Compound 4: middle estimate off by 2.4-fold (0.38 log units), on the high side, and the stated range covers the measured number.
By their numbers in this assay, from the lowest: compounds 2, 1, 4 and 3 (each within the scatter of the next, the first and the last beyond it).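

In this assay, the step at this saturated chain carbon, where 2,5-dioxoimidazolidin-4-yl takes the place of the group in compound 1, is a 1.2-fold higher number from compound 1 to compound 4 (0.07 log units; within the scatter). Going by these compounds alone, this is the first comparison that is confined to one place, and it shows that the alkylidene link of compound 1 is not needed to keep the number within the scatter in this assay. Nothing on record bears on why the two groups read alike.

Going by these compounds, whether a carboxylic acid or an amine at this same carbon would also keep the number remains open. Neither compound 2 nor compound 3 is linked to compound 4 by a one-place step, so the same change in their ring type also remains unread.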